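A Shorter Branched Ester Chain: Compound 3 to Compound 4

The compounds below may be only part of what the source reports. "The series", "measured", "known", "first", "only" and "open" are said of these compounds alone.

Compound 1, `CC(=O)OCCO[C@H](CC=C(C)C)C1=CC(=O)c2c(O)ccc(O)c2C1=O`, gives 15500 nM in a functional assay on DU-145 cells (Homo sapiens) for cytotoxicity, read by MTT assay; a lower number here means a stronger inhibitor, a higher number a weaker inhibitor.
Compound 2, `CC(C)=CC[C@@H](OC(=O)C1CCOC1)C1=CC(=O)c2c(O)ccc(O)c2C1=O`, gives 47500 nM in this assay.
Compound 3, `CCCCC(C)(O)CC(=O)O[C@H](CC=C(C)C)C1=CC(=O)c2c(O)ccc(O)c2C1=O`, gives 76500 nM in this assay.

Compound 3 has the highest number of the three. Its nearest neighbour is compound 2, and the step of a 1.6-fold higher number from compound 2 to compound 3 (0.21 log units; within the scatter) lies within the scatter, so the two cannot be told apart. Against compound 1 the gap is real: a 4.9-fold higher number from compound 1 to compound 3 (0.69 log units; beyond the scatter).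

Compound 4 is `CCC(O)(CC)CC(=O)O[C@H](CC=C(C)C)C1=CC(=O)c2c(O)ccc(O)c2C1=O`. It differs from compound 3 in one place: 1-ethyl-1-hydroxypropyl in place of 1-hydroxy-1-methylpentyl on a saturated chain carbon bound to a carbonyl carbon. Within the data shown here, the only measured step that touches the chain on the carbonyl carbon is a 1.6-fold higher number from compound 2 to compound 3 (0.21 log units; within the scatter), and it stayed within the scatter; the steps of a 3.1-fold higher number from compound 1 to compound 2 (0.49 log units; beyond the scatter) and a 4.9-fold higher number from compound 1 to compound 3 (0.69 log units; beyond the scatter) swap the whole group on the oxygen and say little about rearranging carbons inside the chain. Nothing here points to a shift in either direction, so the expected step of a 1.1-fold lower number from compound 3 to compound 4 (0.04 log units; within the scatter) is within the scatter. For compound 4 in this assay the estimate is 70000 nM, with a range from 30000 nM to 170000 nM.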

Compound 4, half-maximal inhibitory concentration: 67000 nM
Beside the measured number, compound 4's estimate is 1.0-fold (0.02 log units) above it; the measured number falls inside the stated range.
By their numbers in this assay, from the lowest: compound 1; then compounds 2, 4 and 3 (each within the scatter of the next).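

Replacing 1-hydroxy-1-methylpentyl (7 heavy atoms) with 1-ethyl-1-hydroxypropyl (6 heavy atoms) on a saturated chain carbon bound to a carbonyl carbon reshapes the chain, yet in this assay the result is a 1.1-fold lower number from compound 3 to compound 4 (0.06 log units; within the scatter) and no real change can be read from it. Compound 4 also cannot be told apart from the oxolan-3-yl ester, with a 1.4-fold higher number from compound 2 to compound 4 (0.15 log units; within the scatter) as the step, whereas a 4.3-fold higher number from compound 1 to compound 4 (0.64 log units; beyond the scatter) keeps compound 1 and its 2-acetoxyethyl group clearly apart from compound 4. No supporting evidence is available to explain these numbers.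

Both branched chains shown carry a hydroxy group, so the effect of a plain alkyl chain at this position remains open. It is also unknown whether an amine, a carboxylic acid or a longer chain would shift the number.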